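Moving a chlorine around the terminal phenyl ring

This account rests on a few compounds, and the source may have more. Where it says the series, first, only, none or still open, it means among the compounds named here.

Compound 2 `CC(C)N1CCc2nc(C#Cc3ccccc3Cl)ccc2C1=O` is tested in a functional assay on HEK293 cells for negative allosteric modulation of metabotropic glutamate receptor 5 (Homo sapiens), read by FLIPR and calcium flux (a higher number here means a weaker inhibitor, a lower number a stronger inhibitor), where compound 2 gives 2520 nM. Among the measured compounds shown here, that is the higher of the two numbers measured so far. For the measured compounds named here, the only other measured compound is compound 1 `CC(C)N1CCc2nc(C#Cc3ccccc3)ccc2C1=O`, which in this assay gives 706 nM. Going by the values given here, the one measured step, a 3.6-fold higher number from compound 1 to compound 2 (0.55 log units; beyond the scatter), therefore places compound 2 as the weaker of the two.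

Compound 3 `CC(C)N1CCc2nc(C#Cc3ccc(Cl)cc3)ccc2C1=O` keeps the same atoms but joins them differently: 4-chlorophenyl in place of 2-chlorophenyl on a triple-bonded carbon. The chlorine thus stays on the terminal phenyl ring and only changes where it sits. Among the compounds with values here, no measured step compares two positions of a substituent on that ring; the step from compound 1 to compound 2 shows only what adding the chlorine did, and it was modest. With nothing to say whether the new position is better or worse than the old, the expectation for compound 3 is a number near that of compound 2, with a wide range, and the step of a 1.7-fold lower number from compound 2 to compound 3 (0.23 log units; within the scatter) is expected to lie within the scatter. For compound 3 the estimate in this assay is 1500 nM, between 400 nM and 6000 nM.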

Compound 3, half-maximal inhibitory concentration: 4230 nM
Compound 3: middle estimate off by 2.8-fold (0.45 log units), on the low side, within the range that was stated.
By their numbers in this assay, from the lowest: compound 1; then compounds 2 and 3 (each within the scatter of the next).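

In this assay, moving the chlorine from 2-chlorophenyl to 4-chlorophenyl gives a 1.7-fold higher number from compound 2 to compound 3 (0.22 log units; within the scatter), so these two placements on the terminal ring cannot be told apart. Measured against the plain phenyl ring, the new placement gives a 6.0-fold higher number from compound 1 to compound 3 (0.78 log units; beyond the scatter), which shows that the loss seen with the first chlorine is not confined to one place: compound 2 and compound 3 both give higher numbers than compound 1, and so both are weaker inhibitors. Nothing measured here bears on what lies behind this loss.

The compounds shown leave open whether the loss belongs to chlorine itself or would appear with any group on the terminal phenyl ring, and a fluoro, a methoxy or an amine in the same places would help to separate those two readings. Also open, going by these compounds, is whether any group on this ring can bring the number below that of compound 1, rather than merely leaving it unchanged or raising it.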